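Dichlorophenyl for Bromophenyl: An Expected Step in Ear Inhibition

A few compounds are considered here, and "the series" means these few. Any claim that something is new, unique, unknown or untested is made for them only; others in the source may bear on it.

Compound 1 `O=C(/C=C/c1ccc(/C=N/NC(=O)c2ccncc2)cc1)c1ccc(F)cc1` — 51.1%
Compound 2 `O=C(/C=C/c1ccc(/C=N/NC(=O)c2ccncc2)cc1)c1ccc(Br)cc1` — 55.7%
Compound 3 `N=C(N)N/N=C/c1ccc(/C=C/C(=O)c2ccc(Br)cc2)cc1` — 68.9%

Of the compounds shown here, three have been measured in a functional assay on the whole organism (Ear) for inhibition, with Mus musculus as the target, with a stated time of 30 min, at a dose of 100 mg/kg by the intraperitoneal route; on this read-out lower numbers stand for less inhibition and higher numbers for more inhibition at the one dose given (going by the name of the read-out). Compound 2 stands second highest of the three. Its nearest neighbour is compound 1, and the step of a number 4.6 percentage points higher from compound 1 to compound 2 (within the scatter) lies within the scatter, so the two cannot be told apart. The step of a number 13.2 percentage points higher from compound 2 to compound 3 (beyond the scatter) is beyond the scatter, and compound 3 stands furthest from compound 2.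

Compound 4 `O=C(N/N=C/c1ccc(/C=C/C(=O)c2ccc(Cl)cc2Cl)cc1)c1ccncc1` has not yet been measured. Compared with compound 2 it differs as follows: 2,4-dichlorophenyl in place of 4-bromophenyl on a carbonyl carbon. Among the compounds with values here, of the measured steps, only the one from compound 1 to compound 2 touches the same phenyl ring, and there the exchange of one halogen for another gave a number 4.6 percentage points higher from compound 1 to compound 2 (within the scatter), a change within the scatter. The step from compound 2 to compound 3 alters a different part of the shared core and so does not bear on this exchange. On that basis no step beyond the scatter is expected for compound 4 in this assay; the expected step is a number 0.7 percentage points lower from compound 2 to compound 4 (within the scatter). For compound 4 the estimate is 55%, expected to fall between 42% and 68%.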

Compound 4, a percentage reported as inhibition, in the whole organism at one dose (the size of the read-out at that dose, not a potency): 83.8%
Estimate against measurement, compound 4: 28.8 percentage points below; measured number above the stated range.
By their numbers in this assay, from the lowest: compounds 1 and 2 (each within the scatter of the next); then compound 3; then compound 4.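

In this assay, the aryl group on the carbonyl carbon turns out to be a place where the read-out can shift well beyond the scatter: 2,4-dichlorophenyl in place of 4-bromophenyl gives a number 28.1 percentage points higher from compound 2 to compound 4 (beyond the scatter), and the same group in place of 4-fluorophenyl gives a number 32.7 percentage points higher from compound 1 to compound 4 (beyond the scatter). Within the data shown here, the earlier exchange at this place, bromo for fluoro, gave only a number 4.6 percentage points higher from compound 1 to compound 2 (within the scatter), so the one halogen swap on the ring had not revealed how much this position can change the outcome, and the two steps to compound 4 now show that it can. Nothing available explains the gain or separates the part played by the second chlorine from that played by chlorine taking the place of bromine.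

The compounds shown leave open whether a phenyl ring carrying a single chlorine would already reach such a number or both chlorines are needed, and how a methoxy group or an amine on the same ring would fare. They also leave open whether 2,4-dichlorophenyl would raise the number in the same way on the core of compound 3.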